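Hydroxy on the shared core and trifluoromethoxy versus hydroxy

This account rests on a few compounds, and the source may have more. Where it says the series, first, only, none or still open, it means among the compounds named here.

Compound 1 `FC(F)(F)Oc1ccc(-c2ccc(-c3ccc(-c4nc5ccccc5[nH]4)cc3)cc2)cc1` gives 38000 nM in a functional assay on A549 cells (Homo sapiens) for inhibition, read by sulforhodamine B assay; on this read-out higher numbers stand for weaker inhibition of growth and lower numbers for stronger inhibition of growth. Compound 2 `Oc1ccc(-c2ccc(-c3ccc(-c4nc5ccccc5[nH]4)cc3)cc2)cc1` gives 33100 nM in this assay, the change being (hydrogen in place of trifluoromethyl on an oxygen on an aromatic ring), and the step is a 1.1-fold lower number from compound 1 to compound 2 (0.06 log units; within the scatter). Compound 3 `Oc1cccc2[nH]c(-c3ccc(-c4ccc(-c5ccc(OC(F)(F)F)cc5)cc4)cc3)nc12` gives 190 nM in this assay; it differs from compound 1 by hydroxy in place of hydrogen on an aromatic carbon, and the step is a 200-fold lower number from compound 1 to compound 3 (2.30 log units; beyond the scatter).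

Compound 4 `Oc1ccc(-c2ccc(-c3ccc(-c4nc5c(O)cccc5[nH]4)cc3)cc2)cc1` is not yet measured. It differs from compound 3 by hydrogen in place of trifluoromethyl on an oxygen on an aromatic ring, the same change as from compound 1 to compound 2, made on the same place; the two cores differ by hydroxy in place of hydrogen on an aromatic carbon. Since the earlier step was a 1.1-fold lower number from compound 1 to compound 2 (0.06 log units; within the scatter), the step for compound 4 is expected to be no change at the digits printed from compound 3 to compound 4 (within the scatter), resting on that one measured pair alone. Compound 4 is therefore estimated at 190 nM in this assay, expected between 80 nM and 500 nM.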

Compound 4, concentration for 50% growth inhibition: 170 nM
Beside the measured number, compound 4's estimate is 1.1-fold (0.05 log units) above it; the range from low to high includes it.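

In this assay, hydrogen in place of trifluoromethyl on the oxygen gives a 1.1-fold lower number from compound 3 to compound 4 (0.05 log units; within the scatter), so this change carries over from one core to the other: the same change on two cores in this assay, a 1.1-fold lower number (0.06 log units; within the scatter) from compound 1 to compound 2 and a 1.1-fold lower number (0.05 log units; within the scatter) from compound 3 to compound 4, 1.0-fold (0.01 log units) apart, within the scatter of two such steps

The hydroxy on the core carries over in the same way, with the hydroxy-ended pair showing a 190-fold lower number from compound 2 to compound 4 (2.29 log units; beyond the scatter): the same change on two cores in this assay, a 200-fold lower number (2.30 log units; beyond the scatter) from compound 1 to compound 3 and a 190-fold lower number (2.29 log units; beyond the scatter) from compound 2 to compound 4, 1.0-fold (0.01 log units) apart, within the scatter of two such steps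

This holds for these four compounds in this one assay; it does not show that either change would carry over to other cores, and it gives no reason for the large step.

Open, going by these compounds, is whether an amine or a methoxy in place of the hydroxy on the core would keep that large step. Also open, on these data alone, is whether a carboxylic acid in place of the trifluoromethoxy would leave the number unmoved.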